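Anilino-thiosemicarbazone series: chloro to methoxy on the aryl ring

The source may hold more compounds than are shown below. What is called first, only, known or untested is meant among the compounds shown, and "the series" means these compounds.

Going by the values given here, compound 1 `CCN(CC)CN1C(=O)/C(=N/NC(=S)Nc2ccc(Cl)cc2)c2ccccc21` is the only member of the series with a numerical reading in an ADME assay on Vero cells (Chlorocebus sabaeus) for cytotoxicity (a lower number here means that less compound is tolerated, a higher number that more compound is tolerated), where compound 1 gives 20000 nM. Among the compounds with values here, compound 2 `CCN(CC)CN1C(=O)/C(=N/NC(N)=S)c2cc(Cl)ccc21` reaches only a limit of the assay in this assay, with compound 2 recorded at > 100000 nM; this is the limit of > 100000 nM in this assay, at which 1 of the 2 values shown sits, so no measured step can be drawn between the two. Compound 3 `CCN(CC)CN1C(=O)/C(=N/NC(=S)Nc2ccc(OC)cc2)c2ccccc21` is not yet measured in this assay. It differs from compound 1 in one place, (methoxy in place of chloro on an aromatic carbon). With no measured step of this kind in the series, the expectation rests on compound 1 alone, and the step of a 1.3-fold higher number from compound 1 to compound 3 (0.10 log units; within the scatter) is expected to stay within the usual scatter, with no clear direction. Compound 3 is therefore estimated at 25000 nM in this assay, with a range from 8000 nM to 100000 nM.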

Compound 3, minimum cytotoxic concentration: 4000 nM
For compound 3 the middle estimate is 6.3-fold (0.80 log units) above the measured one, outside the stated range (below it).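

In this assay, the change from 4-chlorophenyl to 4-methoxyphenyl is not neutral: the series now has its first measured step, a 5.0-fold lower number from compound 1 to compound 3 (0.70 log units; beyond the scatter), and it points towards less compound being tolerated. The substituent on this aromatic carbon, para to a large group, therefore affects the read-out, and replacing chloro with methoxy is enough to move the number beyond the scatter. Nothing measured here gives a cause for this step.

Steps involving compound 2 cannot be read, as its value of > 100000 nM is a limit of the assay. From the compounds shown here alone, it remains open whether an amine, a carboxylic acid, a methyl group or a longer alkoxy chain at this position would continue this shift, and whether one measured pair reflects a wider trend across the series.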